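This account rests on a few compounds, and the source may have more. Where it says the series, first, only, none or still open, it means among the compounds named here.

Measured so far:
compound 1 `CC(C)c1nc(N)c2nn(-c3ccccc3)cc2n1`: 2%
compound 2 `Nc1nc(Cc2cccc(C(F)(F)F)c2)nc2cn(-c3ccccc3)nc12`: 1%
compound 3 `Nc1nc(CCCc2ccc(OCc3ccccc3)cc2)nc2cn(-c3ccccc3)nc12`: 14%

Three compounds share the core and are read in an assay on CHO cells for displacement of a labelled ligand from adenosine receptor A1 (Homo sapiens), read by scintillation counting, tested at 1 uM; on this read-out lower numbers stand for less inhibition and higher numbers for more inhibition at the one concentration tested (going by the name of the read-out). Compound 3 stands highest of the three numbers; its nearest neighbour is compound 1, lower by a margin beyond the scatter, and compound 2 lies furthest, also beyond the scatter. Within the data shown here, no pair among the measured compounds differs in a single place, so no measured step is available as a guide.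

Compound 4 `C=CCOc1ccc(CCCc2nc(N)c3nn(-c4ccccc4)cc3n2)cc1` is the next compound, differing from compound 3 by vinyl in place of phenyl on a saturated chain carbon bound to an oxygen on an aromatic ring. The change is small in atom count and adds no donor or acceptor. The step expected a number 4 percentage points lower from compound 3 to compound 4 (within the scatter) is within the scatter, with no clear direction. Compound 4 is estimated at 10%, with a range from 2% to 25%.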

Compound 4, a percentage reported as inhibition, at one concentration (the size of the read-out at that concentration, not a potency): 40%
Beside the measured number, compound 4's estimate is 30 percentage points below it; the whole stated range lies below it.
By their numbers in this assay, from the lowest: compounds 2 and 1 (each within the scatter of the next); then compound 3; then compound 4.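

Vinyl in place of phenyl on a saturated chain carbon bound to an oxygen on an aromatic ring gives a number 26 percentage points higher from compound 3 to compound 4 (beyond the scatter) in this assay. This first single-place step shows that the read-out responds to the group at this place, and that the phenyl is not needed for inhibition at the one concentration tested. Nothing available accounts for the size or direction of this step.

As far as these compounds go, whether the double bond matters remains open: an ethyl at this place would separate it from the smaller size of the group. From the compounds shown here alone, how a hydroxyl or an amine at this place would read also remains open.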